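Benzofuran-2-yl in place of ethynyl on the methoxy core

This account rests on a few compounds, and the source may have more. Where it says the series, first, only, none or still open, it means among the compounds named here.

Measured so far in a functional assay on K562 cells (Homo sapiens), read by MTT assay, with a stated time of 72 h; on this read-out lower numbers stand for stronger inhibition and higher numbers for weaker inhibition:
compound 1 `Nc1nc(N)c2c(-c3ccsc3)cn([C@@H]3O[C@H](CO)[C@@H](O)[C@H]3O)c2n1` gives > 20000 nM
compound 2 `Nc1nc(N)c2c(-c3cc4ccccc4o3)cn([C@@H]3O[C@H](CO)[C@@H](O)[C@H]3O)c2n1` gives 18600 nM
compound 3 `C#Cc1cn([C@@H]2O[C@H](CO)[C@@H](O)[C@H]2O)c2ncnc(OC)c12` gives 300 nM

The value of compound 1 is a limit of this assay, not a number. Compound 3 stands lowest of the two numbers; its nearest neighbour is compound 2, and that gap lies beyond the scatter. Compound 4 `COc1ncnc2c1c(-c1cc3ccccc3o1)cn2[C@@H]1O[C@H](CO)[C@@H](O)[C@H]1O` carries the change (1-benzofuran-2-yl in place of ethynyl on an aromatic carbon). Among the compounds with values here, the one measured step, an at least 1.0-fold lower number from compound 1 to compound 2 (0.03 log units; that floor lies within the scatter), puts 1-benzofuran-2-yl in place of thiophen-3-yl on a different core and lies within the scatter, so no measured step bears directly on this change. Compound 4 is therefore expected near compound 3, with a step of a 1.3-fold higher number from compound 3 to compound 4 (0.12 log units; within the scatter) and wide uncertainty. The estimate for compound 4 is 400 nM, ranging from 50 nM to 4000 nM.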

Compound 4, half-maximal inhibitory concentration: 20900 nM
For compound 4 the middle estimate is 52-fold (1.72 log units) below the measured one, and the stated range ends below it.
By their numbers in this assay, from the lowest: compound 3; then compounds 2 and 4 (each within the scatter of the next).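

Replacing ethynyl with 1-benzofuran-2-yl on this aromatic carbon of the methoxy core gives a 70-fold higher number from compound 3 to compound 4 (1.84 log units; beyond the scatter), so the group here can decide much of the inhibition on this core. The earlier step, on another core, could not show this, because it lay within the scatter and rested on a limit: the limit of > 20000 nM in this assay, at which 1 of the 4 values shown sits.

As far as these compounds go, how a nitrile or a propyl chain on this carbon would compare with ethynyl stays open. So does whether ethynyl on the core of compound 1 would give as low a number as on the methoxy core.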